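Halogen exchange on two benzothiazole-type cores: chloro to bromo

This account rests on a few compounds, and the source may have more. Where it says the series, first, only, none or still open, it means among the compounds named here.

Compound 1 `COc1ccc(-c2nc3cc(F)ccc3s2)cc1Cl` and compound 2 `COc1ccc(-c2nc3cc(F)ccc3s2)cc1Br` share one core and differ only in one halogen. In a functional assay on MDA-MB-468 cells (Homo sapiens) for antiproliferative activity (a lower number here means a stronger inhibitor of growth, a higher number a weaker inhibitor of growth), compound 1 gives 480 nM, and compound 2 gives 420 nM. The change between them, (bromo in place of chloro on an aromatic carbon), made a step of a 1.1-fold lower number from compound 1 to compound 2 (0.06 log units; within the scatter).

Compound 3 `COc1ccc(-c2nc3cc(Cl)ccc3s2)cc1OC` stands on a second core; how the two cores differ is not broken down here. In this assay compound 3 gives 1000 nM, the highest number of the three, beyond the scatter from both compound 1 and compound 2.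

Compound 4 `COc1ccc(-c2nc3cc(Br)ccc3s2)cc1OC` is not yet measured. It differs from compound 3 by bromo in place of chloro on an aromatic carbon. This is the same kind of change as that from compound 1 to compound 2, though the surroundings differ: in compound 1 the carbon bearing the halogen is ortho to a methoxy group and meta to a large group, whereas in compound 3 it is part of a fused or bridged system of two rings, meta to a fused ring and para to a fused ring.

For compound 4 in this assay a step of a 1.1-fold lower number from compound 3 to compound 4 (0.05 log units; within the scatter) is expected, because the step of a 1.1-fold lower number from compound 1 to compound 2 (0.06 log units; within the scatter) stayed within the scatter, and the core of compound 3 offers no separate evidence. Compound 4 is therefore estimated at 900 nM, with a range from 450 nM to 1800 nM.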

Compound 4, concentration for 50% growth inhibition: 770 nM
Beside the measured number, compound 4's estimate is 1.2-fold (0.07 log units) above it, within the range that was stated.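

In this assay, the exchange of chloro for bromo on the core of compound 3 gives a 1.3-fold lower number from compound 3 to compound 4 (0.11 log units; within the scatter), a step that stays within the scatter. Set beside the same exchange on the core of compound 1, this step shows no difference between the two cores: the same change on two cores in this assay, a 1.1-fold lower number (0.06 log units; within the scatter) from compound 1 to compound 2 and a 1.3-fold lower number (0.11 log units; within the scatter) from compound 3 to compound 4, 1.1-fold (0.06 log units) apart, within the scatter of two such steps. For these two pairs, then, chloro and bromo are interchangeable within the scatter, but two small steps do not show that the same holds on other cores, and they do not separate the effect of the core from the setting of the halogen, since the halogen-bearing carbon lies in a different setting in each pair.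

The compounds shown leave open what happens when something other than a second heavy halogen occupies the halogen position, for example an amine, a carboxylic acid or a longer alkyl chain. Also open is what the fluoro of compound 1 and the second methoxy of compound 3 each contribute on their own, as no pair shown isolates either group.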